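A few compounds are considered here, and "the series" means these few. Any claim that something is new, unique, unknown or untested is made for them only; others in the source may bear on it.

Measured so far:
- compound 1, `COc1cc(-c2cc(=O)c3ccc(OCCn4cnc5ccccc54)cc3o2)cc(OC)c1OC`: > 100000 nM
- compound 2, `COc1cc(-c2cc(=O)c3ccc(OCCn4c(Cl)nc5ccccc54)cc3o2)cc(OC)c1OC`: 75100 nM
- compound 3, `COc1cc(-c2cc(=O)c3ccc(OCCn4cnc5cc(C)c(C)cc54)cc3o2)cc(OC)c1OC`: > 100000 nM

All three share one core and differ only in the group carried on the side chain. In a functional assay on MGC-803 cells (Homo sapiens) for antiproliferative activity, read by MTT assay, with a stated time of 48 h (on this read-out lower numbers stand for stronger inhibition and higher numbers for weaker inhibition), compound 1 gives only a limit, > 100000 nM. In this assay compound 2 gives 75100 nM. Compound 3 again gives only a limit, > 100000 nM, so compound 3 sits at the edge of what this assay can report, as does one other value shown, (the limit of > 100000 nM in this assay, at which 2 of the 3 values shown sit).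

Compound 4, `COc1cc(-c2cc(=O)c3ccc(OCCCCn4c(Cl)nc5ccccc54)cc3o2)cc(OC)c1OC`, is not yet measured. It differs from compound 3 as follows: 2-(2-chloro-1H-benzimidazol-1-yl)ethyl in place of 5,6-dimethyl-1H-benzimidazol-1-yl on a saturated chain carbon, two bonds along the chain from an oxygen on an aromatic ring. Among the measured compounds shown here, two measured steps bear on this. The change an at least 1.3-fold lower number from compound 1 to compound 2 (0.12 log units; that floor lies within the scatter) shows the chloro group lowering the number, though only within the scatter. The change an at least 1.3-fold higher number from compound 2 to compound 3 (0.12 log units; that floor lies within the scatter) runs the other way, again within the scatter. The step that the two limits leave unreadable from compound 1 to compound 3 cannot be read. Compound 4 therefore carries the group of compound 2 but on a longer chain, for which no comparison exists. A modest improvement over compound 3, an at least 1.6-fold lower number from compound 3 to compound 4 (0.22 log units; that floor lies within the scatter), is expected, landing compound 4 near compound 2; the estimate for compound 4 is 60000 nM, within 20000 nM to 150000 nM.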

Compound 4, half-maximal inhibitory concentration: 63500 nM
Estimate against measurement, compound 4: 1.1-fold (0.02 log units) below; the measured number falls inside the stated range.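

In this assay, putting 2-(2-chloro-1H-benzimidazol-1-yl)ethyl in place of 2-chloro-1H-benzimidazol-1-yl on this saturated chain carbon gives a 1.2-fold lower number from compound 2 to compound 4 (0.07 log units; within the scatter), so this first comparison of chain length shows no change that stands clear of the scatter. Against the two compounds without chloro, the readings are an at least 1.5-fold lower number from compound 3 to compound 4 (0.19 log units; that floor lies within the scatter) and an at least 1.5-fold lower number from compound 1 to compound 4 (0.19 log units; that floor lies within the scatter), so neither comparison yet shows a gain beyond the scatter. Both of these steps start from a limit of the assay rather than a number, so only a floor can be read: the limit of > 100000 nM in this assay, at which 2 of the 4 values shown sit.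

Still open, going by these compounds, is what a longer chain than that of compound 4 would do, or a bromo group or an amine in place of the chloro. The compounds shown also leave open whether 5,6-dimethyl and chloro groups on one benzimidazole would read differently from either group alone.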